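Swapping the side-chain amide for a cyclic carbamate

The compounds below may be only part of what the source reports. "The series", "measured", "known", "first", "only" and "open" are said of these compounds alone.

Compound 1 `CC(C)(O/N=C(\C(=O)N[C@@H]1C(=O)N(S(=O)(=O)O)[C@@H]1CNC(=O)CN)c1csc(N)n1)C(=O)O` carries a ((aminomethyl)carbonyl)amino group on a saturated chain carbon bound to a saturated ring carbon. In a physicochemical assay for metabolic stability, read by HPLC and mass spectrometry, in phosphate buffer, at 37 degrees C, at pH 7.4 (a lower number here means that the compound disappears faster, a higher number that the compound lasts longer), compound 1 gives 149 h. Its two neighbours differ from it in that one place: compound 2 `CN(C[C@@H]1[C@H](NC(=O)/C(=N\OC(C)(C)C(=O)O)c2csc(N)n2)C(=O)N1S(=O)(=O)O)C(=O)CN` gives 212 h in this assay, a step of a 1.4-fold higher number from compound 1 to compound 2 (0.15 log units; within the scatter), and compound 3 `CC(C)(O/N=C(\C(=O)N[C@@H]1C(=O)N(S(=O)(=O)O)[C@@H]1Cn1cncn1)c1csc(N)n1)C(=O)O` gives 233 h, a step of a 1.6-fold higher number from compound 1 to compound 3 (0.19 log units; within the scatter); compound 1 therefore sits with the others, its steps to both within the scatter. Compound 4 `CC(C)(O/N=C(\C(=O)N[C@@H]1C(=O)N(S(=O)(=O)O)[C@@H]1CN1C[C@@H](CN)OC1=O)c1csc(N)n1)C(=O)O` is not yet measured; it differs from compound 1 by a group of 8 heavy atoms (4 carbon, 2 nitrogen, 2 oxygen; one five-membered non-aromatic ring with 2 hetero atoms) in place of a group of 5 heavy atoms (2 carbon, 2 nitrogen, 1 oxygen; no ring), on a saturated chain carbon bound to a saturated ring carbon. Since neither step from compound 1 moved beyond the scatter, compound 4 is expected to show no step beyond the scatter either, an estimated 1.1-fold higher number from compound 1 to compound 4 (0.06 log units; within the scatter). Compound 4 is estimated at 170 h, within 105 h to 270 h.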

Compound 4, half-life: > 37 h
Compound 4 was reported as a limit (the forecaster's own chance of this, stated with the estimate: 0%); the middle value lies beyond the limit too.
By their numbers in this assay, from the lowest: compounds 1, 2 and 3 (each within the scatter of the next).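

In this assay compound 4 gives > 37 h, a limit and not a number. Its steps from compound 1, compound 2 and compound 3 cannot be read. The compounds shown leave open how compound 4 truly compares with those three.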